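Removing the acetyl group from compound 2

The source may report more compounds than this note shows. Statements on the series, on what has been measured and on what is new or still open speak of the compounds shown alone.

In a functional assay for inhibition, with Rattus norvegicus as the target (a lower number here means a stronger inhibitor, a higher number a weaker inhibitor), compound 1 (`CCc1c(CC)c(OC)c2c(ccn2C)c1OC(C)=O`) gives 2030 nM, while compound 2 (`CCCCc1cc(OC)c2sccc2c1OC(C)=O`) gives 460 nM. Compound 2 thus holds the lower of the two numbers, and the gap between them lies beyond the scatter. Compound 3 (`CCCCc1cc(OC)c2sccc2c1O`) has not yet been measured. It has hydrogen in place of acetyl on an oxygen on an aromatic ring, acetoxy to hydroxy: hydrogen in place of acetyl on an oxygen on an aromatic ring. Among the measured compounds shown here, no measured pair shows this change, so the expectation in this assay rests on the structural change alone, and no step beyond the scatter is expected. The expected step is a 1.3-fold higher number from compound 2 to compound 3 (0.12 log units; within the scatter). For compound 3 the estimated value is 600 nM, with a range of 180 nM to 2000 nM.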

Compound 3, half-maximal inhibitory concentration: 1050 nM
For compound 3 the middle estimate is 1.8-fold (0.24 log units) below the measured one; the measured number falls inside the stated range.
By their numbers in this assay, from the lowest: compound 2; then compounds 3 and 1 (each within the scatter of the next).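

In this assay, putting hydrogen in place of acetyl on this oxygen gives a 2.3-fold higher number from compound 2 to compound 3 (0.36 log units; beyond the scatter) and so costs some inhibition, though the step is modest. Among the compounds shown here, this is the only pair in the set that differs in one place, which shows that acetoxy and hydroxy are not interchangeable here, at least on the core of compound 2. No measurement at hand accounts for the step.

On these data alone, whether a methyl ether or a longer acyl chain on this oxygen would match acetoxy remains open. So does whether the same change on the core of compound 1 would give a similar step.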